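The source may report more compounds than this note shows. Statements on the series, on what has been measured and on what is new or still open speak of the compounds shown alone.

Compound 1 `C=CCOCCn1c(N2CCCN(C)CC2)nc2ccccc21` gives in a functional assay on ileum for inhibition of histamine H1 receptor (Cavia porcellus) (on this read-out lower numbers stand for stronger inhibition and higher numbers for weaker inhibition), a value of 10 nM.
Compound 2 `CCOCCn1c(N2CCN(CC)CC2)nc2ccccc21` gives in this assay a value of 18 nM.
Compound 3 `C#CCOCCn1c(N2CCN(C)CC2)nc2ccccc21` gives in this assay a value of 12 nM.

Among these three numbers, compound 3 holds the second highest, yet its gap to compound 1 and its gap to compound 2 both fall within the usual scatter of repeated measurements, so on these data the three compounds cannot be told apart. Compound 4 `CN1CCN(c2nc3ccccc3[nH]2)CC1` has not yet been measured. It differs from compound 3 in one place: hydrogen in place of 2-(propargyloxy)ethyl on an aromatic nitrogen. Going by the values given here, no pair of measured compounds shows what removing this side chain does, and the measured compounds differ from one another in more than one place, so they offer no single-change comparison to lean on. Losing the whole side chain is a large change, and the expectation is a step in this assay toward weaker inhibition, clearly larger than the scatter. For compound 4 the estimate is 500 nM, with a range from 100 nM to 3000 nM. The step that this estimate means, a 42-fold higher number from compound 3 to compound 4 (1.62 log units; beyond the scatter), is expected to lie well beyond the scatter.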

Compound 4, half-maximal inhibitory concentration: > 3000 nM
Compound 4 gave a limit, no number (the forecaster's own chance of this, stated with the estimate: 15%); middle value at least 6.0-fold (0.77 log units) away from the limit.
By their numbers in this assay, from the lowest: compounds 1, 3 and 2 (each within the scatter of the next). At a limit, above all of these: compound 4.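

In this assay compound 4 gives > 3000 nM, which is a limit of the assay and not a number. Going by these compounds alone, putting hydrogen in place of 2-(propargyloxy)ethyl on the aromatic nitrogen gives an at least 250-fold higher number from compound 3 to compound 4 (2.39 log units; beyond the scatter), a large step and the first single-change comparison. The earlier compounds shown here all carry an ether side chain on this nitrogen and sit within the scatter of one another, so only this result shows that inhibition in this assay depends heavily on having a side chain at this position.

Which part of the side chain is needed remains open: a plain methyl or a 2-hydroxyethyl group on the same nitrogen would help to separate the effect of chain length from that of the ether oxygen and the triple bond. Going by these compounds, the full size of the step also remains unknown.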